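Thiophen-2-yl in Place of 4-Cyanobutyl

The compounds below may be only part of what the source reports. "The series", "measured", "known", "first", "only" and "open" are said of these compounds alone.

Of the compounds shown here, two have been measured so far in a physicochemical assay for solubility, in phosphate buffer, with a stated time of 18 h; on this read-out higher numbers stand for higher solubility and lower numbers for lower solubility. Compound 1 (`N#Cc1c(N)nc2nc(C3CC3)ncc2c1N`) gives 23000 nM in this test. Compound 2 (`CC(C)(C)c1nc(CCCCC#N)c2c(N)c(C#N)c(N)nc2n1`) gives 16000 nM and thus stands within the scatter of compound 1, so the two numbers cannot be told apart. The next compound to be measured is compound 3 (`CC(C)(C)c1nc(-c2cccs2)c2c(N)c(C#N)c(N)nc2n1`), which carries thiophen-2-yl in place of 4-cyanobutyl on an aromatic carbon. Going by the values given here, the two measured compounds differ in more than one place, so they offer no direct precedent for this exchange, and any forecast remains a judgement with a wide margin. A modest downward move, somewhat beyond the scatter, is expected, with an estimated 2.3-fold lower number from compound 2 to compound 3 (0.36 log units; beyond the scatter) in this assay. Compound 3 is therefore expected to give about 7000 nM (estimated range 2500 nM to 18000 nM).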

Compound 3, solubility: 56000 nM
Estimate against measurement, compound 3: 8.0-fold (0.90 log units) below, and the stated range ends below it.
By their numbers in this assay, from the lowest: compounds 2 and 1 (each within the scatter of the next); then compound 3.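

In this assay, thiophen-2-yl in place of 4-cyanobutyl on this aromatic carbon, next to the ring nitrogen, gives a 3.5-fold higher number from compound 2 to compound 3 (0.54 log units; beyond the scatter), a modest step beyond the scatter. Going by these compounds alone, this is the only comparison here between compounds differing in one place, and it shows that this position can take a five-membered aromatic ring in place of a chain with no ring, with the number going up rather than down. Nothing shown here bears on why the number moves in this direction.

As far as these compounds go, whether the step comes from the entry of thiophen-2-yl or the departure of 4-cyanobutyl remains open, as does the effect of phenyl, a shorter alkyl chain or an amine at this position. Also open, from the compounds shown here alone, is whether the same exchange would move the number in the same direction with a group other than tert-butyl on the shared core.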